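The source may hold more compounds than are shown below. What is called first, only, known or untested is meant among the compounds shown, and "the series" means these compounds.

Measured so far in the series:
Compound 1 `Oc1ccc(-c2cc(-c3ccc(F)cc3)cc(-c3ccccc3O)n2)cc1` gives only a limit, > 50000 nM.
Compound 2 `Oc1ccc(-c2cc(-c3ccc(F)cc3)cc(-c3cccc(O)c3)n2)cc1` gives 5020 nM.
Compound 3 `Oc1ccccc1-c1cc(-c2ccc(OC(F)(F)F)cc2)cc(-c2ccccc2O)n1` gives only a limit, > 50000 nM.

All values come from a functional assay on HCT-15 cells (Homo sapiens) for inhibition; a lower number here means a stronger inhibitor, a higher number a weaker inhibitor. Compound 1 sits at the limit of this assay, (the limit of > 50000 nM in this assay, at which 2 of the 3 values shown sit). Going by the values given here, the one step measured, an at least 9.9-fold lower number from compound 1 to compound 2 (0.99 log units; beyond the scatter), goes with 3-hydroxyphenyl in place of 2-hydroxyphenyl on an aromatic carbon. The difference between the core of compound 1 and the core of compound 3 is not broken down here. Compound 4 `Oc1cccc(-c2cc(-c3ccc(OC(F)(F)F)cc3)cc(-c3ccccc3O)n2)c1` has not been measured; it differs from compound 3 by 3-hydroxyphenyl in place of 2-hydroxyphenyl on an aromatic carbon. This is the same kind of change as from compound 1 to compound 2, but the surroundings differ: in compound 1 the carbon is meta to a 4-fluorophenyl group and meta to a 4-hydroxyphenyl group, whereas in compound 3 it is meta to a 2-hydroxyphenyl group and meta to a large group. For compound 4 a step of an at least 6.2-fold lower number from compound 3 to compound 4 (0.79 log units; beyond the scatter) in this assay is expected, resting on an at least 9.9-fold lower number from compound 1 to compound 2 (0.99 log units; beyond the scatter) and on the limit of > 50000 nM in this assay, at which 2 of the 3 values shown sit, at which compound 3 stands. The estimate for compound 4 in this assay is 8000 nM, between 2000 nM and 50000 nM.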

Compound 4, half-maximal inhibitory concentration: 9410 nM
For compound 4 the middle estimate is 1.2-fold (0.07 log units) below the measured one; measured number inside the range.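

In this assay, 3-hydroxyphenyl in place of 2-hydroxyphenyl on a second core goes with an at least 5.3-fold lower number from compound 3 to compound 4 (0.72 log units; beyond the scatter). The change therefore carries over in direction, with both steps beyond the scatter, but the values of compound 1 and compound 3 are limits, so neither step has an exact size. Whether the change is worth the same on the two cores stays undecided: the same change on two cores in this assay, an at least 9.9-fold lower number (0.99 log units; beyond the scatter) from compound 1 to compound 2 and an at least 5.3-fold lower number (0.72 log units; beyond the scatter) from compound 3 to compound 4; the limit leaves it open whether they differ

Open, going by these compounds, is how a 3-aminophenyl or 3-methoxyphenyl group would compare with 3-hydroxyphenyl at this place. Also open, on these data alone, is what a second 3-hydroxyphenyl group, in place of the remaining 2-hydroxyphenyl group of compound 4, would give.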